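Compound 4: a dichlorophenyl isomer among assay limits

The compounds below may be only part of what the source reports. "The series", "measured", "known", "first", "only" and "open" are said of these compounds alone.

In an ADME assay on HCT-116 cells (Homo sapiens) for cytotoxicity, read by CellTiter-Glo, with a stated time of 72 h (a lower number here means a stronger inhibitor, a higher number a weaker inhibitor), compound 1 (`CC1CCN(C2CCN(S(=O)(=O)c3cccnc3F)CC2)CC1`) gives > 10000 nM as a limit of the assay. Compound 2 (`CC1CCN(C2CCN(S(=O)(=O)c3nccn3C)CC2)CC1`) gives > 10000 nM as a limit too. Compound 3 (`CC1CCN(C2CCN(S(=O)(=O)c3cc(Cl)cc(Cl)c3)CC2)CC1`) gives > 5000 nM as a limit as well, so it has no exact number. The change to compound 4 (`CC1CCN(C2CCN(S(=O)(=O)c3ccc(Cl)cc3Cl)CC2)CC1`) is 2,4-dichlorophenyl in place of 3,5-dichlorophenyl on a sulfonyl sulfur and places 2,4-dichlorophenyl in place of 3,5-dichlorophenyl on a sulfonyl sulfur. The measured steps bearing on it are a step that the two limits leave unreadable from compound 1 to compound 3 and a step that the two limits leave unreadable from compound 2 to compound 3 and neither gives a size. No shift beyond the scatter is therefore expected, and no direction can be favoured, so the expected step is a step that the limit leaves unreadable from compound 3 to compound 4 in this assay for now. For compound 4 the estimate is 8000 nM with an expected range of 3000 nM to 20000 nM and a limit is the likeliest report.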

Compound 4, half-maximal inhibitory concentration: > 5000 nM
Compound 4 gave a limit, no number; the forecaster's own chance of this, stated with the estimate: 80%; the middle value lies beyond the limit too.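

Compound 4, like compounds 1, 2 and 3, gives only a limit in this assay, so none of its steps from those three compounds can be read. The compounds shown leave open whether the 2,4-dichlorophenyl and 3,5-dichlorophenyl groups differ at all in this read-out.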